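The source may report more compounds than this note shows. Statements on the series, on what has been measured and on what is new or still open speak of the compounds shown alone.

In a functional assay on BXPC-3 cells (Homo sapiens) for antiproliferative activity, read by MTT assay, with a stated time of 24 h (a higher number here means a weaker inhibitor, a lower number a stronger inhibitor), compound 1 `CCn1c(C(=O)N[C@H](C)C(=O)O)ccc1C(CC)(CC)c1ccc(OCS(=O)(=O)c2ccccc2)c(C)c1` gives 20100 nM. Compound 2 `CCn1c(C(=O)N[C@H](CC(=O)O)C(=O)O)ccc1C(CC)(CC)c1ccc(OCS(=O)(=O)c2ccccc2)c(C)c1` reads > 50000 nM, which is a limit of the assay and not a number. Compound 3 `CCn1c(C(=O)N[C@H](CCC(=O)O)C(=O)O)ccc1C(CC)(CC)c1ccc(OCS(=O)(=O)c2ccccc2)c(C)c1` carries carboxymethyl in place of carboxy on a saturated chain carbon, two bonds along the chain from an amide-type nitrogen and a carbonyl carbon. Among the compounds with values here, the one measured step bearing on this is an at least 2.4-fold higher number from compound 1 to compound 2 (0.39 log units; beyond the scatter), where carboxy replaced hydrogen on that same carbon. The acid group stays in compound 3, so the expected step, a number no higher from compound 2 to compound 3 (the limit leaves the size open), is none beyond the scatter. For compound 3 the estimate is 50000 nM, with an expected range of 20000 nM to 120000 nM.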

Compound 3, half-maximal inhibitory concentration: > 50000 nM
Compound 3 was reported as a limit; the forecaster's own chance of this, stated with the estimate: 60%; the middle value sits exactly at the limit.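

In this assay compound 3 gives > 50000 nM, which is a limit of the assay and not a number. Carboxymethyl in place of hydrogen on this saturated chain carbon gives an at least 2.4-fold higher number from compound 1 to compound 3 (0.39 log units; beyond the scatter), so the second acid group raises the number on the longer chain as well as on the shorter one. The step between the two limits cannot be read, and carboxy and carboxymethyl cannot be ordered at this position: the limit of > 50000 nM in this assay, at which 2 of the 3 values shown sit.

As far as these compounds go, how an amine or a hydroxy group on this chain compares with compound 1 at 20100 nM stays open. From the compounds shown here alone, how far compound 2 and compound 3 lie past the limit also stays open.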